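Pyrrolidine for cyclohexylmethylamine on the shared core

The compounds below may be only part of what the source reports. "The series", "measured", "known", "first", "only" and "open" are said of these compounds alone.

Three measured members of the series share one core and differ only in the amine attached to it. Compound 1 `O=C(CCc1ccc(C(F)(F)F)cc1)Nc1ccc2nc(N3CCC(NS(=O)(=O)O)C3)ccc2c1` gives 50 nM in a functional assay on HEK293 cells for activation of melanin-concentrating hormone receptor 1 (Rattus norvegicus), read by inositol phosphate accumulation; on this read-out lower numbers stand for an effect already at smaller amounts and higher numbers for an effect only at larger amounts of compound. Compound 2 `O=C(CCc1ccc(C(F)(F)F)cc1)Nc1ccc2nc(N3CC4CC3CN4)ccc2c1` gives 490 nM in this assay. Compound 3 `CN(c1ccc2cc(NC(=O)CCc3ccc(C(F)(F)F)cc3)ccc2n1)C1CCCCC1` gives 1200 nM in this assay and thus stands highest of the three numbers, with a 2.4-fold higher number from compound 2 to compound 3 (0.39 log units; beyond the scatter) and a 24-fold higher number from compound 1 to compound 3 (1.38 log units; beyond the scatter).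

Compound 4 `CC1CCCN1c1ccc2cc(NC(=O)CCc3ccc(C(F)(F)F)cc3)ccc2n1` differs from compound 3 by 2-methylpyrrolidin-1-yl in place of cyclohexyl(methyl)amino on an aromatic carbon. Both measured steps into compound 3 bear on this change, since each exchanged the amine at the same place and each replaced a ring amine by cyclohexyl(methyl)amino: a 24-fold higher number from compound 1 to compound 3 (1.38 log units; beyond the scatter) was large and a 2.4-fold higher number from compound 2 to compound 3 (0.39 log units; beyond the scatter) modest. Compound 4 reverses the direction, but its 2-methylpyrrolidin-1-yl lacks the sulfoamino group of compound 1 and the second nitrogen of compound 2, so only part of those gains is expected to return. A modest lowering, a 2.0-fold lower number from compound 3 to compound 4 (0.30 log units; within the scatter), is expected. For compound 4 the estimate in this assay is 600 nM, within a range from 200 nM to 2000 nM.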

Compound 4, half-maximal effective concentration: 270 nM
For compound 4 the middle estimate is 2.2-fold (0.35 log units) above the measured one; the range from low to high includes it.
By their numbers in this assay, from the lowest: compound 1; then compounds 4 and 2 (each within the scatter of the next); then compound 3.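

In this assay, a pyrrolidine ring carrying only a methyl already gives a clear change from cyclohexyl(methyl)amino (a 4.4-fold lower number from compound 3 to compound 4 (0.65 log units; beyond the scatter)), without the sulfoamino group of compound 1 or the second ring nitrogen of compound 2. The two-ring group of compound 2 cannot be told apart from 2-methylpyrrolidin-1-yl (a 1.8-fold lower number from compound 2 to compound 4 (0.26 log units; within the scatter)), whereas 3-(sulfoamino)pyrrolidin-1-yl remains clearly separate (a 5.4-fold higher number from compound 1 to compound 4 (0.73 log units; beyond the scatter)), so at this position the sulfoamino-bearing ring stands apart from the other two ring amines. Nothing at hand accounts for these differences.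

The step into compound 4 changes the ring and the methyl together, so the share of each remains unresolved. Plain pyrrolidin-1-yl would separate them, and a carboxylic acid on the pyrrolidine ring would test whether the sulfoamino group can be replaced.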